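This account rests on a few compounds, and the source may have more. Where it says the series, first, only, none or still open, it means among the compounds named here.

Measured in an ADME assay on MDCKII-LE cells (Canis lupus familiaris) for permeability; on this read-out lower numbers stand for lower permeability and higher numbers for higher permeability:
- compound 1 `Cc1ccc(Oc2cc(C(=O)Nc3cnc(C)cn3)cc3oc(C)cc23)cc1`: 0.3 10^-6 cm/s
- compound 2 `Cc1cnc(NC(=O)c2cc(Oc3ccc(C#N)cc3)c3cc(C)oc3c2)cn1`: 1.5 10^-6 cm/s

Of these two, compound 2 has the higher number, 1.5 10^-6 cm/s. Compound 3 `Cc1cnc(NC(=O)c2cc(Oc3ccc(C(=O)N(C)C)cc3)c3cc(C)oc3c2)cn1` keeps the core of compound 2 and changes one group: dimethylcarbamoyl in place of cyano on an aromatic carbon. Dimethylcarbamoyl takes the place of cyano on an aromatic carbon, para to a large group.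

Among the measured compounds shown here, only one measured step bears on this: a 5.0-fold higher number from compound 1 to compound 2 (0.70 log units; beyond the scatter), with cyano in place of methyl on an aromatic carbon. It shows that a swap of this kind can move the number beyond the scatter. However, no measured step involves dimethylcarbamoyl, and a single step sets no trend. In this assay I therefore expect no change beyond the scatter, with only a slight lean downward. The expected step is a 1.5-fold lower number from compound 2 to compound 3 (0.18 log units; within the scatter). For compound 3 the estimated value is 1 10^-6 cm/s, with an expected range of 0.3 10^-6 cm/s to 3.5 10^-6 cm/s.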

Compound 3, apparent permeability: 5.9 10^-6 cm/s
Estimate against measurement, compound 3: 5.9-fold (0.77 log units) below; measured number outside the range, above it.
By their numbers in this assay, from the lowest: compound 1; then compound 2; then compound 3.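

In this assay, dimethylcarbamoyl in place of cyano gives a 3.9-fold higher number from compound 2 to compound 3 (0.59 log units; beyond the scatter), and dimethylcarbamoyl in place of methyl gives a 20-fold higher number from compound 1 to compound 3 (1.29 log units; beyond the scatter). Among the compounds shown here, the earlier compounds showed only one change at this position, on an aromatic carbon para to a large group, and a single step could set no trend. Now a second swap at the same place moves the number beyond the scatter in the same direction, and the group that enters here is the largest of the three, with five heavy atoms against two for cyano.

On these data alone, whether an amine, a carboxylic acid or a longer chain at this position would follow the same direction remains open. Nothing available here gives a reason for the rise from one group to the next.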